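This account rests on a few compounds, and the source may have more. Where it says the series, first, only, none or still open, it means among the compounds named here.

Working notes on the series. For the measured compounds named here, in a functional assay on B16-F10 cells (Mus musculus) for cytotoxicity, read by MTT assay, with a stated time of 72 h (a lower number here means a stronger inhibitor, a higher number a weaker inhibitor), compound 2 `COc1ccc2[nH]c3c4cn[nH]c4c4c(c3c2c1)C(=O)NC4=O` gives 37000 nM, which is so far the only measured number. The other result is a limit of the assay and not a number: compound 1 `c1ccc2[nH]c(-n3cccn3)cc2c1` is recorded at > 100000 nM. Compound 2 therefore has no numerical comparator, and its value has to serve as the sole anchor.

The next compound is compound 3 `Cc1ccc2[nH]c3c4cn[nH]c4c4c(c3c2c1)C(=O)NC4=O`, which keeps the core of compound 2 and carries methyl in place of methoxy on an aromatic carbon, meta to a fused ring and para to a fused ring: methyl in place of methoxy on an aromatic carbon. Going by the values given here, no measured pair differs in one place, so the size of this swap in this assay has not been observed directly. With only the value of 37000 nM for compound 2 to go on, no shift beyond the scatter is expected in either direction. The expected change is a 1.1-fold lower number from compound 2 to compound 3 (0.05 log units; within the scatter). For compound 3 the estimate is 33000 nM, with an expected range of 11000 nM to 95000 nM.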

Compound 3, half-maximal inhibitory concentration: 2000 nM
Estimate against measurement, compound 3: 17-fold (1.22 log units) above; measured number outside the range, below it.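

In this assay, this place on the aromatic carbon, meta to a fused ring and para to a fused ring, turns out to be sensitive to its substituent: methyl in place of methoxy gives a 19-fold lower number from compound 2 to compound 3 (1.27 log units; beyond the scatter). For the compounds shown here, this is the first one-place change measured, and it shows that the shared core responds to a small edit at this position by well beyond the usual scatter. Methoxy leaves with 2 heavy atoms and 1 hydrogen-bond acceptor, and methyl enters with 1 heavy atom and 0 hydrogen-bond acceptors, but nothing measured on these compounds accounts for the size of the step.

The compounds shown leave open how a bare hydrogen, a chlorine atom, a hydroxyl or an ethyl group at this place would compare with methyl and methoxy, and so whether the step follows the oxygen atom or the size of the group. They also leave open whether the same swap would give a step of similar size at another place on the shared core.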